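Pyrrolidinyl in place of ethyl on the shared aryl core

The source may report more compounds than this note shows. Statements on the series, on what has been measured and on what is new or still open speak of the compounds shown alone.

Of the compounds shown here, three sharing one cyanoacrylic acid core have been measured in an assay on RBE4 cells for inhibition of Monocarboxylate transporter 1 (Rattus norvegicus), with a stated time of 15 min; a lower number here means a stronger inhibitor, a higher number a weaker inhibitor. Compound 1 `CCc1ccc(/C=C(\C#N)C(=O)O)cc1` gives 500 nM and sits at the upper end of the three numbers. Compound 3 `C#CCN(CC#C)c1ccc(/C=C(\C#N)C(=O)O)cc1` gives 400 nM in this assay, a difference from compound 1 that lies within the usual scatter. Compound 2 `CC(C)CN(CC(C)C)c1ccc(/C=C(\C#N)C(=O)O)cc1` gives 100 nM in this assay, a gap from compound 1 that lies beyond the scatter.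

Compound 4 `N#C/C(=C\c1ccc(N2CCCC2)cc1)C(=O)O` has not yet been measured in this assay. Its structure differs from compound 1 in one place: pyrrolidin-1-yl in place of ethyl on an aromatic carbon. Going by the values given here, no direct step between measured compounds isolates this change. Compounds 2 and 3 both carry a nitrogen on that aromatic carbon, and their numbers in this assay fall at or beneath that of compound 1, so a move to a lower number is expected for compound 4, likely of modest size, near or just beyond the scatter. Compound 4 is therefore estimated at 200 nM in this assay, with a range from 60 nM to 700 nM. The step this estimate implies, a 2.5-fold lower number from compound 1 to compound 4 (0.40 log units; beyond the scatter), is expected to be a decrease in number.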

Compound 4, half-maximal inhibitory concentration: 70 nM
The estimate for compound 4 lay 2.9-fold (0.46 log units) above the measured number; low and high end bracket the measured number.
By their numbers in this assay, from the lowest: compounds 4 and 2 (each within the scatter of the next); then compounds 3 and 1 (each within the scatter of the next).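

In this assay, going by these compounds alone, pyrrolidin-1-yl in place of ethyl on the aromatic carbon gives a 7.1-fold lower number from compound 1 to compound 4 (0.85 log units; beyond the scatter) and this is the first step at this position that can be read directly, as the earlier compounds offered no pair differing in one place. It shows that this position accepts a five-membered non-aromatic ring attached through its nitrogen, and that the number falls beyond the scatter with this single change. Compound 4 at 70 nM and compound 2 at 100 nM lie within the scatter of each other, so a ring on the nitrogen and two open branched chains on it give values that cannot be told apart here. No measurement on hand explains the step.

A cyclopentyl group at the same position would show whether the nitrogen or the carbon ring goes with the lower number, and a dimethylamino group would show what a small open amine gives there. Piperidin-1-yl and morpholin-4-yl would test whether the size of the ring and a second hetero atom in it change the number.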